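This account rests on a few compounds, and the source may have more. Where it says the series, first, only, none or still open, it means among the compounds named here.

Measured compounds:
- Compound 1, `Cc1cc(O)c(C(=O)/C=C/c2cccc(Cl)c2)c(-c2ccccc2)c1C(=O)/C=C/c1cccc(Cl)c1`: in an ADME assay on HEK293 cells (Homo sapiens) for cytotoxicity, read by MTT assay, with a stated time of 24 h (a lower number here means a stronger inhibitor, a higher number a weaker inhibitor), compound 1 gives 15000 nM
- Compound 2, `COc1ccc(/C=C/C(=O)c2c(C)cc(O)c(C(=O)/C=C/c3ccc(OC)cc3)c2-c2ccccc2)cc1`: in this assay compound 2 gives "not active" (no number reported)
- Compound 3, `Cc1cc(O)c(C(=O)/C=C/c2ccc(OCc3ccccc3)cc2)c(-c2ccc(Br)cc2)c1C(=O)/C=C/c1ccc(OCc2ccccc2)cc1`: in this assay compound 3 gives 25000 nM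

Compound 2 stands apart from the other two on these numbers, in that no single number was reported for it in this assay; the only word attached to it is that it showed no activity, so it cannot be placed in order against compound 1 or compound 3.

Compound 4, `COc1ccc(/C=C/C(=O)c2c(C)cc(O)c(C(=O)/C=C/c3ccc(OC)cc3)c2-c2ccc(Br)cc2)cc1`, has not yet been measured. It is made from compound 2 by a single change: bromo in place of hydrogen on an aromatic carbon. In words, bromo takes the place of hydrogen on an aromatic carbon of the ring attached to the shared core.

Among the compounds with values here, no measured pair differing only in this way is available, so the size of the step can only be guessed. Some shift toward a lower number seems plausible because compound 3 with the same 4-bromophenyl group gives 25000 nM in this assay, while compound 2 with the plain phenyl gave no number at all. Compound 4 is therefore expected to give about 40000 nM, within a range from 15000 nM to 150000 nM.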

Compound 4, half-maximal inhibitory concentration: "not active" (no number reported)
No number was reported for compound 4, so the estimate cannot be set against anything.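

In this assay compound 2 and compound 4 were both reported as not active, with no number for either, so no step can be read between them. Nothing measured here bears on this result. The compounds shown leave open whether going from phenyl to 4-bromophenyl changes the read-out at all.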